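A few compounds are considered here, and "the series" means these few. Any claim that something is new, unique, unknown or untested is made for them only; others in the source may bear on it.

Measured compounds:
- compound 1 `COc1ccc(OC)c(/C=N/NC(=O)Nc2ccc(Oc3ccnc(-c4nncn4CCN(C)C)c3)c(F)c2)c1`: in an ADME assay on WI-38 cells (Homo sapiens) for cytotoxicity, read by MTT assay, with a stated time of 72 h (on this read-out higher numbers stand for weaker inhibition and lower numbers for stronger inhibition), compound 1 is recorded as "not determined" (no result reported)
- compound 2 `CN(C)CCn1cnnc1-c1cc(Oc2ccc(NC(=O)N/N=C/c3c(O)ccc4ccccc34)cc2F)ccn1`: in this assay compound 2 gives 3250 nM

Going by the values given here, compound 1 thus stands nowhere on the numbers of this assay: no result was reported for it, and no step between measured compounds is available for comparison. Compound 2 is the only anchor, and it shares the core with compound 1 but carries a different group on the carbon with a double bond to nitrogen, so the two values cannot be set side by side as a step.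

Compound 3 `CN(C)CCn1cnnc1-c1cc(Oc2ccc(NC(=O)N/N=C/c3c[nH]c4ccccc34)cc2F)ccn1` differs from compound 1 by 1H-indol-3-yl in place of 2,5-dimethoxyphenyl on a carbon with a double bond to nitrogen. Among the compounds with values here, with no measured step for this change, the expectation rests on compound 2 alone, whose 3250 nM suggests that compounds of this core sit in the micromolar range of this assay; any shift in this assay from compound 1 to compound 3 cannot be sized beyond the scatter from the data at hand. Compound 3 is expected to give about 4000 nM in this assay, with a range from 1500 nM to 12000 nM.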

Compound 3, half-maximal inhibitory concentration: 3620 nM
For compound 3 the middle estimate is 1.1-fold (0.04 log units) above the measured one; low and high end bracket the measured number.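

Going by these compounds alone, the first readable step at this position in this assay is a 1.1-fold higher number from compound 2 to compound 3 (0.05 log units; within the scatter), so 1H-indol-3-yl and 2-hydroxynaphthalen-1-yl on the carbon with a double bond to nitrogen cannot be told apart on this read-out. With the shared core held constant, this exchange of two quite different groups, one of which carries the ring nitrogen with its hydrogen-bond donor, moves the number by no more than the usual scatter. No supporting measurement bears on this result.

Any step from compound 1 cannot be read, so the place of 2,5-dimethoxyphenyl relative to these two groups stays unknown. Also open, as far as these compounds go, is how a saturated amine such as piperidine, a carboxylic acid or a longer alkyl chain on this carbon would read in this assay.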